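The source may report more compounds than this note shows. Statements on the series, on what has been measured and on what is new or still open speak of the compounds shown alone.

Of the compounds shown here, three have been measured in a physicochemical assay for acid dissociation. Compound 1 `Fc1ccc(Cc2ccc3c(NCCCNCc4ccco4)ccnc3c2)c(Cl)c1` gives 9.47, compound 2 `FC(F)(F)c1ccc(-c2ccc3c(NCCCNCc4ccco4)ccnc3c2)cc1` gives 9.47, and compound 3 `COc1cccc(Oc2ccc3c(NCCCNCc4ccco4)ccnc3c2)c1` gives 9.28. Compound 3 thus stands at the lower end of the three numbers shown, yet its gaps to compound 1 and to compound 2 both lie within the scatter, so the three cannot be ranked. Each step that swaps the group on the aromatic carbon has been flat: no change at the digits printed from compound 1 to compound 2 (within the scatter), a number 0.19 log units lower from compound 1 to compound 3 (within the scatter) and a number 0.19 log units lower from compound 2 to compound 3 (within the scatter).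

Compound 4 `CN(C)c1cccc(Oc2ccc3c(NCCCNCc4ccco4)ccnc3c2)c1` takes the next step from compound 3: dimethylamino in place of methoxy on an aromatic carbon. The change again touches only the group on an aromatic carbon, the same place where every measured step stayed inside the scatter. The expected step is therefore a number 0.07 log units higher from compound 3 to compound 4 (within the scatter), nothing beyond the scatter. Compound 4 is estimated at 9.35, with a range from 8.95 to 9.75.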

Compound 4, acid dissociation constant: 9.28
Compound 4: middle estimate off by 0.07 log units, on the high side, and the stated range covers the measured number.
By their numbers in this assay, from the lowest: compounds 3, 4, 1 and 2 (each within the scatter of the next).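

In this assay, dimethylamino in place of methoxy gives no change at the digits printed from compound 3 to compound 4 (within the scatter) and so adds a small edit within one group, on an aromatic carbon meta to a large group, to the earlier swaps of the whole group. The wider comparisons stay flat as well, with a number 0.19 log units lower from compound 2 to compound 4 (within the scatter) and a number 0.19 log units lower from compound 1 to compound 4 (within the scatter), so 3-(dimethylamino)phenoxy joins the groups at this place that cannot be told apart in this read-out. Nothing at hand gives a reason for this flatness.

From the compounds shown here alone, whether a carboxylic acid or a longer chain ending in an amine at this place would move the number beyond the scatter remains open. So does the outcome of a change elsewhere, such as an amide in the chain on the shared core.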